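A few compounds are considered here, and "the series" means these few. Any claim that something is new, unique, unknown or untested is made for them only; others in the source may bear on it.

In an ADME assay on L02 cells (Homo sapiens) for inhibition, read by CCK-8 assay, with a stated time of 48 h (on this read-out lower numbers stand for stronger inhibition of growth and higher numbers for weaker inhibition of growth), compound 1 (`CN1CCN(c2ccc(Nc3ncc(Cl)c(NCc4ccccc4)n3)nc2)CC1`) gives 20300 nM, compound 2 (`COc1ccccc1CNc1nc(Nc2ccc(N3CCN(C)CC3)cn2)ncc1Cl`) gives 25500 nM and compound 3 (`CN1CCN(c2ccc(Nc3ncc(Cl)c(NCc4ccco4)n3)nc2)CC1`) gives 45700 nM. Compound 3 separates only from compound 1, with a 2.3-fold higher number from compound 1 to compound 3 (0.35 log units; beyond the scatter), a modest step. Both a 1.8-fold higher number from compound 2 to compound 3 (0.25 log units; within the scatter) and a 1.3-fold higher number from compound 1 to compound 2 (0.10 log units; within the scatter) stay within the scatter. Compound 4 (`Cc1ccc(Nc2nc(Nc3ccc(N4CCN(C)CC4)cn3)ncc2Cl)cc1`) has 4-methylphenyl in place of (furan-2-yl)methyl on a nitrogen on an aromatic ring. Among the compounds with values here, no measured step makes this exact change, so the guidance is loose. Read in reverse, the modest step from phenyl to furan-2-yl suggests that a six-membered ring may bring a similar move towards a lower number. The expected change is a 2.1-fold lower number from compound 3 to compound 4 (0.32 log units; beyond the scatter). For compound 4, the estimated value is 22000 nM, within an expected range of 9000 nM to 50000 nM.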

Compound 4, concentration for 50% growth inhibition: 13900 nM
For compound 4 the middle estimate is 1.6-fold (0.20 log units) above the measured one, and the stated range covers the measured number.
By their numbers in this assay, from the lowest: compounds 4, 1, 2 and 3 (each within the scatter of the next, the first and the last beyond it).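

In this assay, 4-methylphenyl in place of (furan-2-yl)methyl on this nitrogen gives a 3.3-fold lower number from compound 3 to compound 4 (0.52 log units; beyond the scatter), a modest step beyond the scatter. Against the other two groups, the same 4-methylphenyl gives a 1.8-fold lower number from compound 2 to compound 4 (0.26 log units; within the scatter) and a 1.5-fold lower number from compound 1 to compound 4 (0.16 log units; within the scatter), both within the scatter, so in this small set the (4-methylphenyl)amino group reads no differently from the 2-methoxybenzyl or benzyl versions. Nothing here gives a measured reason for these steps. Going by these compounds, how a saturated amine such as morpholine or a carboxylic acid on the phenyl ring would read at this position remains open.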